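The compounds below may be only part of what the source reports. "The series", "measured", "known", "first", "only" and "open" are said of these compounds alone.

Measured in a functional assay on NCI-H226 cells (Homo sapiens) for inhibition, read by MTT assay, with a stated time of 48 h, tested at 10 uM; a higher number here means more inhibition at the concentration tested (going by the name of the read-out), a lower number less inhibition:

Compound 1 `COc1ccc(Br)cc1Nc1cc(NC(=O)Nc2c(Cl)cccc2Cl)ncn1`: 33%
Compound 2 `COc1cc(NC(=O)Nc2cc(Nc3cc(Br)ccc3OC)ncn2)cc(OC)c1`: 42.7%
Compound 3 `Cc1ccc(Nc2cc(NC(=O)Nc3c(Cl)cccc3Cl)ncn2)cc1F`: 40.7%

Compound 1 holds the smallest of the three numbers, yet neither gap exceeds the usual scatter: the nearest is compound 3, reached by a number 7.7 percentage points higher from compound 1 to compound 3 (within the scatter), and the furthest is compound 2, reached by a number 9.7 percentage points higher from compound 1 to compound 2 (within the scatter). The three compounds share a common core and differ only in the two aryl groups attached to it.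

Compound 4 `COc1ccc(C(F)(F)F)cc1Nc1cc(NC(=O)Nc2c(Cl)cccc2Cl)ncn1` follows from compound 1 by a single change: trifluoromethyl in place of bromo on an aromatic carbon. Within the data shown here, none of the measured steps repeats this exact replacement. The step from compound 1 to compound 3 is the closer analogy, since it also removes the bromo group, but it swaps the whole aryl ring; the step from compound 1 to compound 2 alters the other aryl group entirely. Both moves stayed within the scatter, so the substituents tried so far have not shifted the read-out in this assay by more than its noise.

Compound 4 is therefore estimated at 38%, with a likely range from 22% to 55%. For compound 4 this means an expected step of a number 5 percentage points higher from compound 1 to compound 4 (within the scatter), within the scatter.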

Compound 4, a percentage reported as inhibition, at one concentration (the size of the read-out at that concentration, not a potency): 60.1%
Beside the measured number, compound 4's estimate is 22.1 percentage points below it; the measured number lies above the stated range.
By their numbers in this assay, from the lowest: compounds 1, 3 and 2 (each within the scatter of the next); then compound 4.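

In this assay, trifluoromethyl in place of bromo on the aromatic carbon para to a methoxy group gives a number 27.1 percentage points higher from compound 1 to compound 4 (beyond the scatter), the only step among those shown that lies beyond the scatter. This shows that the read-out at this position responds to a change of one substituent, whereas the two earlier steps exchanged a whole aryl group and stayed within the scatter. Trifluoromethyl brings 4 heavy atoms where bromo had 1, with no hydrogen-bond donor or acceptor on either side. Nothing available here accounts for the rise.

The compounds shown leave open whether the rise is particular to trifluoromethyl or would also appear with another group at this position, such as a nitrile or an ethyl chain. They also leave open whether the same exchange of bromo for trifluoromethyl would carry over to compound 2, which holds 3,5-dimethoxyphenyl in place of 2,6-dichlorophenyl on the other side of the shared core.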